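Lengthening the Methyl Chain of Compound 2 Toward Compound 4

The source may hold more compounds than are shown below. What is called first, only, known or untested is meant among the compounds shown, and "the series" means these compounds.

Three measured compounds share one core. Compound 1 `COc1cc(F)c(NC(=O)c2ccnc(Cl)c2)cc1Nc1nccc(-c2cn(C)c3ccccc23)n1` gives 4330 nM in a functional assay on NCI-H1975 cells (Homo sapiens) for antiproliferative activity, read by MTT assay, with a stated time of 72 h; on this read-out higher numbers stand for weaker inhibition and lower numbers for stronger inhibition. Compound 2 `COc1cc(N(C)CCN(C)C)c(NC(=O)c2ccnc(Cl)c2)cc1Nc1nccc(-c2cn(C)c3ccccc23)n1` gives 2050 nM in this assay, and compound 3 `COc1cc(N(C)CCN(C)C)c(NC(=O)c2cnccn2)cc1Nc1nccc(-c2cn(C)c3ccccc23)n1` gives 1220 nM in this assay. Among these three numbers compound 2 stands second highest: the step of a 2.1-fold lower number from compound 1 to compound 2 (0.32 log units; beyond the scatter) is beyond the scatter, while the step of a 1.7-fold lower number from compound 2 to compound 3 (0.23 log units; within the scatter) is within it.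

Compound 4 `COc1cc(N(C)CCN(C)C)c(NC(=O)c2ccnc(Cl)c2)cc1Nc1nccc(-c2cn(CCCO)c3ccccc23)n1` differs from compound 2 in a single place: 2-hydroxyethyl in place of hydrogen on a saturated chain carbon bound to an aromatic nitrogen. Neither measured step touches this place. The step from compound 1 to compound 2 exchanges a group on an aromatic carbon, and the step from compound 2 to compound 3 exchanges the group on the carbonyl carbon, so no measured comparison shows what lengthening this chain does. With nothing to guide a direction, the step is expected to stay within the scatter, as a 1.0-fold lower number from compound 2 to compound 4 (0.01 log units; within the scatter). Compound 4 is therefore estimated at 2000 nM in this assay, with a range from 700 nM to 6000 nM.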

Compound 4, half-maximal inhibitory concentration: 1820 nM
For compound 4 the middle estimate is 1.1-fold (0.04 log units) above the measured one; the range from low to high includes it.
By their numbers in this assay, from the lowest: compounds 3, 4 and 2 (each within the scatter of the next); then compound 1.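

Adding 2-hydroxyethyl on the saturated chain carbon bound to an aromatic nitrogen, which can also be read as methyl becoming 3-hydroxypropyl, gives a 1.1-fold lower number from compound 2 to compound 4 (0.05 log units; within the scatter) in this assay. Among the compounds shown here, this is the first view of this place, since compounds 1, 2 and 3 all carry methyl there, and it shows that the longer chain, with its hydrogen-bond donor and acceptor, leaves compound 4 within the scatter of compound 2. Nothing at hand accounts for this result.

As far as these compounds go, whether a chain ending in an amine or a carboxylic acid, or a chain longer than 3-hydroxypropyl, would fit here as readily remains open. So does whether the 3-hydroxypropyl chain would behave the same alongside the pyrazin-2-yl group of compound 3.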